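A weak series and one further substitution

The source may hold more compounds than are shown below. What is called first, only, known or untested is meant among the compounds shown, and "the series" means these compounds.

Of the compounds shown here, three have been measured so far, and none of them inhibits strongly. In a functional assay on MCF7 cells (Homo sapiens) for inhibition, read by sulforhodamine B assay, with a stated time of 48 h (on this read-out higher numbers stand for weaker inhibition and lower numbers for stronger inhibition), compound 3 `COc1ccc(C(c2ccccc2O)c2cccc3ccccc23)c(OC)c1OC` gives 16600 nM and compound 1 `COc1ccc(C(c2ccc(OC(C)CN(C)C)cc2)c2cccc3ccccc23)c(OC)c1OC` gives 13100 nM, two values that lie within the scatter of each other. Compound 2 `CCOC(=O)/C=C/CO/N=C(/c1ccc(OC)c(OC)c1OC)c1cccc2ccccc12` returned only a limit, > 20000 nM. Compound 3 therefore stands level with compound 1 among the numbers available.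

The next step leads to compound 4 `COc1ccc(C(OCc2ccc(C)cc2)c2cccc3ccccc23)c(OC)c1OC`, which carries (4-methylbenzyl)oxy in place of 2-hydroxyphenyl on a saturated chain carbon bound to two aromatic carbons. Within the data shown here, no two measured compounds differ in one place only, so the size of this change cannot be read directly from the data. Compound 1 at 13100 nM and compound 3 at 16600 nM carry different groups yet remain within the scatter, so no step beyond the scatter is expected in this assay. The expected step is a 1.1-fold higher number from compound 3 to compound 4 (0.04 log units; within the scatter), with no firm direction. A reading that returns only a limit, as for compound 2, remains possible. Compound 4 is estimated at 18000 nM, with an expected range from 8000 nM to 40000 nM.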

Compound 4, half-maximal inhibitory concentration: 10700 nM
Compound 4: middle estimate off by 1.7-fold (0.23 log units), on the high side, and the stated range covers the measured number.
By their numbers in this assay, from the lowest: compounds 4, 1 and 3 (each within the scatter of the next). At a limit, above all of these: compound 2.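

In this assay, among these compounds, (4-methylbenzyl)oxy in place of 2-hydroxyphenyl on a saturated chain carbon bound to two aromatic carbons gives a 1.6-fold lower number from compound 3 to compound 4 (0.19 log units; within the scatter), the first step that can be read between two compounds differing in one place. This shows that the exchange can be made at this position without moving the number beyond the scatter, even though the entering group differs in size and linkage and has no hydrogen-bond donor, whereas the group that leaves has one. Compound 2 remains the only compound here that returns a limit rather than a number, while compound 4 stays within the measurable range: the limit of > 20000 nM in this assay, at which 1 of the 4 values shown sits.

Because this single step lies within the scatter, the compounds shown leave open whether this position can influence inhibition at all, and whether the hydroxyl, the methyl or the oxygen link plays any separate part. They also leave open whether a more different group on the same saturated chain carbon, such as a carboxylic acid or a primary amine, would produce a step beyond the scatter.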